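Pyrrole series: cytotoxicity on rat myoblasts

A few compounds are considered here, and "the series" means these few. Any claim that something is new, unique, unknown or untested is made for them only; others in the source may bear on it.

Measured compounds:
- compound 1 `CCOC(=O)C1=C(O)/C(=C\c2cc(C)n(-c3ccc(F)cc3)c2C)N=C1C`: 140000 nM
- compound 2 `CCOC(=O)C1=C(C)N/C(=C/c2cc(C)n(-c3ccc(Br)cc3)c2C)C1=O`: 100000 nM

In an ADME assay on L6 cells (Rattus norvegicus) for cytotoxicity, read by resazurin assay, with a stated time of 72 h (a higher number here means that more compound is needed for the effect, a lower number that less compound is needed), compound 1 gives 140000 nM and compound 2 gives 100000 nM. Compound 2 holds the lower of the two numbers, but its gap to compound 1 lies within the scatter, so the two compounds read as equally weak on this assay, and nothing can be said of an order among them. For the measured compounds named here, no step of this kind has been measured.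

Compound 3 `CCOC(=O)C1=C(C)N/C(=C/c2cc(C)n(-c3cccnc3)c2C)C1=O` differs from compound 2 by one change: pyridin-3-yl in place of 4-bromophenyl on an aromatic nitrogen. Going by the values given here, with no measured step to draw on and both known numbers close together, the expectation is a step of modest size, if any, from compound 2 to compound 3 in this assay, in the direction of a higher number, and an outcome within the scatter would not be surprising; the step expected is a 1.5-fold higher number from compound 2 to compound 3 (0.18 log units; within the scatter). Compound 3 is therefore estimated at 150000 nM, with a range of 60000 nM to 400000 nM.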

Compound 3, half-maximal effective concentration: 160000 nM
For compound 3 the middle estimate is 1.1-fold (0.03 log units) below the measured one; measured number inside the range.
By their numbers in this assay, from the lowest: compounds 2, 1 and 3 (each within the scatter of the next).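

In this assay, for the compounds shown here, the exchange of pyridin-3-yl for 4-bromophenyl on an aromatic nitrogen gives a 1.6-fold higher number from compound 2 to compound 3 (0.20 log units; within the scatter) and is the first step measured at this position. Replacing a ring of carbon only with a ring holding one hetero atom, which adds one hydrogen-bond acceptor, therefore leaves compound 3 indistinguishable from compound 2 on this read-out. Nothing available here bears on the reason for this result.

As far as these compounds go, whether an amine or a carboxylic acid on the aromatic ring at this place, or a longer chain in place of that ring, would give a step beyond the scatter remains open. From the compounds shown here alone, it is also open whether any group at this position can separate a compound from compound 2 in this assay at all.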